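Trimethoxyphenyl for chlorophenyl on the chalcone arm

The compounds below may be only part of what the source reports. "The series", "measured", "known", "first", "only" and "open" are said of these compounds alone.

Measured so far:
compound 1 `O=C(CN1CCN(c2cc3c(cc2F)c(=O)c(C(=O)O)cn3C2CC2)CC1)Nc1ccc(C(=O)/C=C/c2ccccc2)cc1` — 1.29
compound 2 `O=C(CN1CCN(c2cc3c(cc2F)c(=O)c(C(=O)O)cn3C2CC2)CC1)Nc1ccc(C(=O)/C=C/c2ccccc2Cl)cc1` — 1.29
compound 3 `O=C(CN1CCN(c2cc3c(cc2F)c(=O)c(C(=O)O)cn3C2CC2)CC1)Nc1ccc(C(=O)/C=C/c2ccc(Cl)cc2)cc1` — 0.471

In a physicochemical assay for lipophilicity, using the shake flask method, in phosphate buffer, measured as octanol-water partition, with a stated time of 5 h (a higher number here means a more lipophilic compound, a lower number a more polar compound), compound 3 gives the lowest of the three numbers. Its nearest neighbour is compound 1, a number 0.82 log units lower from compound 1 to compound 3 (beyond the scatter), and its furthest is compound 2, a number 0.82 log units lower from compound 2 to compound 3 (beyond the scatter); compound 1 and compound 2 show no change at the digits printed from compound 1 to compound 2 (within the scatter). Compound 4 `COc1cc(/C=C/C(=O)c2ccc(NC(=O)CN3CCN(c4cc5c(cc4F)c(=O)c(C(=O)O)cn5C4CC4)CC3)cc2)cc(OC)c1OC` has not yet been measured in this assay. The change is 3,4,5-trimethoxyphenyl in place of 4-chlorophenyl on a double-bonded chain carbon bound to a double-bonded chain carbon. Among the measured compounds shown here, no measured step exchanges a 4-chlorophenyl for a 3,4,5-trimethoxyphenyl; the only steps at hand, from compound 1 to compound 3 and from compound 2 to compound 3, swap a chloro and a hydrogen or move the chloro, and both gave modest changes. For compound 4 the estimate is therefore a small downward step, a number 0.27 log units lower from compound 3 to compound 4 (within the scatter), uncertain in size, and the expected value is 0.2 within a range of -0.5 to 0.9.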

Compound 4, partition coefficient: 0.753
Compound 4: the middle estimate sits 0.55 log units below what was measured; low and high end bracket the measured number.
By their numbers in this assay, from the lowest: compounds 3 and 4 (each within the scatter of the next); then compounds 1 and 2 (each within the scatter of the next).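

In this assay, 3,4,5-trimethoxyphenyl in place of 4-chlorophenyl on this double-bonded chain carbon brings hydrogen-bond acceptors and more heavy atoms, yet the step stays small (a number 0.28 log units higher from compound 3 to compound 4 (within the scatter)). The same group set against phenyl (a number 0.54 log units lower from compound 1 to compound 4 (beyond the scatter)) and against 2-chlorophenyl (a number 0.54 log units lower from compound 2 to compound 4 (beyond the scatter)) places compound 4 with compound 3, apart from compound 1 and compound 2. Nothing available explains these numbers.

Open, from the compounds shown here alone, is whether a 4-methoxyphenyl, a 4-aminophenyl or a 4-carboxyphenyl at this place would stay with compound 3 and compound 4 or join compound 1 and compound 2.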